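The source may hold more compounds than are shown below. What is called first, only, known or untested is meant among the compounds shown, and "the series" means these compounds.

The measured compounds, each with its result in an in vitro functional assay on CHO/Galpha16 cells for antagonist activity at C-C chemokine receptor type 8 (Homo sapiens), read by FLIPR; a higher number here means a weaker inhibitor, a lower number a stronger inhibitor:

compound 1, `CCCC(=O)N1CCC(NS(=O)(=O)c2ccc(NC(=O)C3CCCCC3)c3ccccc23)CC1`, gives 6.1 nM
compound 2, `CCCC(=O)N1CCC(NS(=O)(=O)c2ccc(NC(=O)c3ccc(C)cc3)c3ccccc23)CC1`, gives 9.5 nM
compound 3, `CCCC(=O)N1CCC(NS(=O)(=O)c2ccc(NC(=O)c3ccc(CC)cc3)c3ccccc23)CC1`, gives 10.8 nM

All three share one core and differ only in the group attached to a carbonyl carbon of the amide. Compound 2 stands second highest of the three numbers, and it sits close to both others: the step of a 1.1-fold higher number from compound 2 to compound 3 (0.06 log units; within the scatter) is within the scatter, and so is a 1.6-fold higher number from compound 1 to compound 2 (0.19 log units; within the scatter). The step of a 1.8-fold higher number from compound 1 to compound 3 (0.25 log units; within the scatter) is likewise within the scatter. Taken together, exchanging cyclohexyl, 4-methylphenyl and 4-ethylphenyl at this position has left the numbers essentially unchanged.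

Compound 4, `CCCC(=O)N1CCC(NS(=O)(=O)c2ccc(NC(=O)c3ccoc3)c3ccccc23)CC1`, has not yet been measured. It differs from compound 2 by furan-3-yl in place of 4-methylphenyl on a carbonyl carbon. As far as these compounds go, the three measured steps bear on it only in part: they show that this position tolerates a change of group, but none of them brings in a five-membered aromatic ring with a hetero atom, so that part of the change is untested here. On that basis a step of a 1.4-fold higher number from compound 2 to compound 4 (0.14 log units; within the scatter) is expected, most likely within the scatter or a little weaker. Compound 4 is therefore estimated at 13 nM, with a range from 5 nM to 35 nM.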

Compound 4, half-maximal inhibitory concentration: 1520 nM
Beside the measured number, compound 4's estimate is 120-fold (2.07 log units) below it; the measured number lies above the stated range.
By their numbers in this assay, from the lowest: compounds 1, 2 and 3 (each within the scatter of the next); then compound 4.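

In this assay, the place on the carbonyl carbon had looked indifferent to the group it carries, but that holds only for cyclohexyl, 4-methylphenyl and 4-ethylphenyl: furan-3-yl brings a 160-fold higher number from compound 2 to compound 4 (2.20 log units; beyond the scatter), a 140-fold higher number from compound 3 to compound 4 (2.15 log units; beyond the scatter) and a 250-fold higher number from compound 1 to compound 4 (2.40 log units; beyond the scatter). All three steps are large and beyond the scatter, whichever of the earlier groups leaves, so the tolerance seen among those groups does not extend to this five-membered aromatic ring with one oxygen as its hetero atom. Nothing available explains the loss, and the change itself combines a smaller ring, fewer heavy atoms, a hetero atom and a hydrogen-bond acceptor, with no measurement that tells these apart.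

The compounds shown leave open which part of the change matters: the five-membered ring as such, the ring oxygen, or the absence of a carbon substituent on the ring. Cyclopentyl, which has a five-membered ring without oxygen, and thiophen-3-yl, which has sulfur in place of the furan oxygen, would each separate part of that question at the same place.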